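A few compounds are considered here, and "the series" means these few. Any claim that something is new, unique, unknown or untested is made for them only; others in the source may bear on it.

Of the compounds shown here, two built on the same core have so far been measured in an assay on isolated protein for binding affinity to 5-hydroxytryptamine receptor 3A (Homo sapiens); on this read-out higher numbers stand for weaker inhibition and lower numbers for stronger inhibition. Compound 1 `Cc1cccc(-c2n[nH]cc2N2CCCNCC2)c1` gives 816 nM in this assay. Compound 2 `COc1cccc(-c2n[nH]cc2N2CCNCC2)c1` gives 2100 nM in this assay, the higher of the two numbers; compound 1 lies a step beyond the scatter below it. Going by the values given here, no pair of measured compounds differs in a single place, so no measured step is available to lean on. Compound 3 `c1ccc(-c2n[nH]cc2N2CCNCC2)cc1` has not been measured. It differs from compound 2 by hydrogen in place of methoxy on an aromatic carbon. Among the compounds with values here, nothing among the measured compounds shows what this change does on its own, and compound 1 differs from compound 2 in more than one place, so its number cannot be read as a guide. The change is therefore expected to give a 1.2-fold lower number from compound 2 to compound 3 (0.07 log units; within the scatter), a step that may well stay within the scatter and whose direction is not firmly predicted. For compound 3 the estimate in this assay is 1800 nM, with a range from 600 nM to 5000 nM.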

Compound 3, inhibition constant: > 10000 nM
Compound 3: only a limit was reported; the forecaster's own chance of this, stated with the estimate: 5%; middle value at least 5.5-fold (0.74 log units) away from the limit.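

In this assay compound 3 reads > 10000 nM, and this value is a limit of the assay, not a number. It supplies the first single-place step in the set, and that step is an at least 4.7-fold higher number from compound 2 to compound 3 (0.67 log units; beyond the scatter), so on this read-out hydrogen does not stand in for methoxy at this place, on an aromatic carbon meta to a large group, and the substituent there is shown to matter for the first time, which neither of the earlier compounds could show alone. The true size of the step remains unknown beyond its lower bound, since only the bound can be read from the value of compound 3: the limit of > 10000 nM in this assay, at which 1 of the 3 values shown sits.

The compounds shown leave open whether the effect belongs to methoxy in particular, as nothing tells how a hydroxyl, an ethoxy or a chlorine at the same place would read, and compound 1, which carries methyl, differs from compound 2 in more than one place and cannot settle it. They also leave open whether the same replacement by hydrogen would cost as much on the core of compound 1.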